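From 4-hydroxypiperidin-1-yl to 3-hydroxypiperidin-1-yl on a sulfonyl sulfur

A few compounds are considered here, and "the series" means these few. Any claim that something is new, unique, unknown or untested is made for them only; others in the source may bear on it.

Compound 1 `O=C(NCc1ccc(S(=O)(=O)c2cccc(C(F)(F)F)c2)cc1)N1Cc2ccncc2C1`: 10000 nM
Compound 2 `O=C(NCc1ccc(S(=O)(=O)c2cncc(C(F)(F)F)c2)cc1)N1Cc2ccncc2C1`: 83000 nM
Compound 3 `O=C(NCc1ccc(S(=O)(=O)N2CCC(O)CC2)cc1)N1Cc2ccncc2C1`: 174000 nM

All three values come from a physicochemical assay for solubility, in phosphate buffer, with a stated time of 24 h, at pH 7.4, tested at 100 uM; on this read-out higher numbers stand for higher solubility and lower numbers for lower solubility. Among these compounds, compound 3 gives the highest number, at 174000 nM. The measured steps are an 8.3-fold higher number from compound 1 to compound 2 (0.92 log units; beyond the scatter), a 17-fold higher number from compound 1 to compound 3 (1.24 log units; beyond the scatter) and a 2.1-fold higher number from compound 2 to compound 3 (0.32 log units; beyond the scatter), and all three lie beyond the scatter.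

Compound 4 `O=C(NCc1ccc(S(=O)(=O)N2CCC[C@@H](O)C2)cc1)N1Cc2ccncc2C1` has not yet been measured. It carries 3-hydroxypiperidin-1-yl in place of 4-hydroxypiperidin-1-yl on a sulfonyl sulfur. Each measured step exchanges one whole substituent on that sulfur for a different one, and none compares two hydroxypiperidines, so the data bear on this change only indirectly. The closest guide is a 2.1-fold higher number from compound 2 to compound 3 (0.32 log units; beyond the scatter), the smallest of the three, yet even that step replaces 5-(trifluoromethyl)pyridin-3-yl with a hydroxypiperidine. A change within the hydroxypiperidine is expected to be smaller, with no shift beyond the scatter in this assay. The expected step is a 1.2-fold lower number from compound 3 to compound 4 (0.06 log units; within the scatter), a slight drop at most. For compound 4 the estimated value is 150000 nM, with an expected range from 75000 nM to 290000 nM.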

Compound 4, solubility: 216000 nM
The estimate for compound 4 lay 1.4-fold (0.16 log units) below the measured number; the measured number falls inside the stated range.
By their numbers in this assay, from the lowest: compound 1; then compound 2; then compounds 3 and 4 (each within the scatter of the next).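

Read in this assay, the result shows that the sulfonyl sulfur carries either hydroxypiperidine without a shift that can be told from the scatter: moving from 4-hydroxypiperidin-1-yl to 3-hydroxypiperidin-1-yl gives (a 1.2-fold higher number from compound 3 to compound 4 (0.09 log units; within the scatter)). Among these compounds, until now, this position had been probed only by exchanging one whole substituent for a very different one, so this is the first comparison made within a single kind of group. The high numbers are therefore not confined to 4-hydroxypiperidin-1-yl, as 3-hydroxypiperidin-1-yl also stands clear of both aromatic groups bearing trifluoromethyl, with (a 2.6-fold higher number from compound 2 to compound 4 (0.42 log units; beyond the scatter)) and (a 22-fold higher number from compound 1 to compound 4 (1.33 log units; beyond the scatter)).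

The compounds shown leave open whether the other stereoisomer of 3-hydroxypiperidin-1-yl would match compound 4, and whether a piperidin-1-yl without the hydroxyl group, or a piperidine ring bearing a carboxylic acid or an amine instead, would keep numbers of this order. Nothing shown here explains why the two hydroxypiperidines stand so close together or why they stand apart from the aromatic groups.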